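From an Amide to a Urea on a Shared Core

This account rests on a few compounds, and the source may have more. Where it says the series, first, only, none or still open, it means among the compounds named here.

Compound 2, `COc1cc(-c2nn(-c3cccc(NC(=O)c4ccc(Cl)c(C(F)(F)F)c4)c3)cc2-c2ccncc2)ccc1Cl`, was examined in a functional assay on OVCAR-4 cells (Homo sapiens) for inhibition, read by sulforhodamine B assay, with a stated time of 48 h; a lower number here means a stronger inhibitor of growth, a higher number a weaker inhibitor of growth. In this assay compound 2 gives > 32500 nM, which is a limit of the assay and not a number. Compound 1, `O=C(Nc1cccc(-n2cc(-c3ccncc3)c(-c3ccc(Cl)c(O)c3)n2)c1)Nc1ccc(Cl)c(Cl)c1`, likewise gives > 32500 nM in this assay, again a limit. Going by the values given here, compound 3, `O=C(Nc1cccc(-n2cc(-c3ccncc3)c(-c3ccc(Cl)c(O)c3)n2)c1)Nc1cc(C(F)(F)F)cc(C(F)(F)F)c1`, gives 5010 nM in this assay, the only number among the three. The other two values sit at the limit of > 32500 nM in this assay, at which 2 of the 3 values shown sit, so compound 2 stands with no number of its own.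

Compound 4, `COc1cc(-c2nn(-c3cccc(NC(=O)Nc4cccc(C(F)(F)F)c4)c3)cc2-c2ccncc2)ccc1Cl`, has not yet been measured. It differs from compound 2 in one place: (3-(trifluoromethyl)phenyl)amino in place of 4-chloro-3-(trifluoromethyl)phenyl on a carbonyl carbon. Among the compounds with values here, no step between two measured compounds is recorded, so the size of the change in this assay can only be estimated. The ureas of compounds 1 and 3 span a limit and a measured number, and compound 4 carries a single trifluoromethyl group on its urea. Compound 4 is expected to remain weak, with an estimated 20000 nM, ranging from 5000 nM to 40000 nM. The expected step is an at least 1.6-fold lower number from compound 2 to compound 4 (0.21 log units; that floor lies within the scatter), with a fair chance that only a limit is reported again.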

Compound 4, concentration for total growth inhibition: 2100 nM
The estimate for compound 4 lay 9.5-fold (0.98 log units) above the measured number, outside the stated range (below it).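

Going by these compounds alone, on the carbonyl carbon, (3-(trifluoromethyl)phenyl)amino in place of 4-chloro-3-(trifluoromethyl)phenyl gives an at least 15-fold lower number from compound 2 to compound 4 (1.18 log units; beyond the scatter) in this assay, the first step in this set between measured compounds that differ in one place. It shows that this position is not silent, since the change turns an amide with only a limit into a urea with a measured number, and the heavy-atom count stays the same while a hydrogen-bond donor enters. The step can be given only as a floor because compound 2 has a limit and no number of its own: the limit of > 32500 nM in this assay, at which 2 of the 4 values shown sit.

The change adds the amino nitrogen and removes the chlorine together, so the compounds shown do not tell which of the two carries the step. On these data alone, how a morpholine or a carboxylic acid in place of the trifluoromethyl group would read also remains open.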